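The source may hold more compounds than are shown below. What is called first, only, known or untested is meant among the compounds shown, and "the series" means these compounds.

Compound 2 `COc1ccc2[nH]c3c(c2c1)CCNC31CCN(Cc2cccc(F)c2F)CC1` sits at the higher of the two numbers available: in an assay on FRT cells for positive allosteric modulation of Cystic fibrosis transmembrane conductance regulator variant N1303K (Homo sapiens), in the presence of a further agent that is not named here (a lower number here means that less compound is needed, a higher number that more compound is needed for the effect), compound 2 gives 13600 nM, while its nearest neighbour, compound 1 `COc1ccc2[nH]c3c(c2c1)CCNC31CCN(Cc2ccccc2Cl)CC1`, gives 2200 nM. Among the compounds with values here, the one step known at this position is a 6.2-fold higher number from compound 1 to compound 2 (0.79 log units; beyond the scatter), which shows that exchanging the ring on the saturated chain carbon bound to the amine nitrogen in the ring can move the number well beyond the scatter. Compound 3 `COc1ccc2[nH]c3c(c2c1)CCNC31CCN(Cc2ccccn2)CC1` differs from compound 2 by pyridin-2-yl in place of 2,3-difluorophenyl on a saturated chain carbon bound to an amine nitrogen in a ring. The step from compound 1 to compound 2 bears on this change in that both alter the same ring, but it gives no direction for a pyridin-2-yl ring; a step of modest size either way is plausible, with a return toward the number of compound 1 somewhat more likely. Compound 3 is expected to give 6000 nM in this assay, between 1500 nM and 25000 nM. That corresponds to an estimated 2.3-fold lower number from compound 2 to compound 3 (0.36 log units; beyond the scatter).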

Compound 3, half-maximal effective concentration: 11500 nM
Compound 3: the middle estimate sits 1.9-fold (0.28 log units) below what was measured, and the stated range covers the measured number.
By their numbers in this assay, from the lowest: compound 1; then compounds 3 and 2 (each within the scatter of the next).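

In this assay, the change to pyridin-2-yl gives a 1.2-fold lower number from compound 2 to compound 3 (0.07 log units; within the scatter), so this exchange at the saturated chain carbon bound to the ring amine nitrogen leaves the number unresolved from that of the 2,3-difluorophenyl ring. Set against the 2-chlorophenyl ring, the same pyridin-2-yl ring gives a 5.2-fold higher number from compound 1 to compound 3 (0.72 log units; beyond the scatter), which shows that two different rings now stand apart from the 2-chlorophenyl ring among these three compounds. No measurement at hand explains this result.

The compounds shown leave open whether the lower number of compound 1 is specific to 2-chlorophenyl or would also appear with 2-bromophenyl, 2-methylphenyl or plain phenyl. They also leave open how a longer chain between the ring amine nitrogen and the aromatic ring would read in this assay.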